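A few compounds are considered here, and "the series" means these few. Any claim that something is new, unique, unknown or untested is made for them only; others in the source may bear on it.

Within the data shown here, compound 2 `O=S(=O)(NCCCNCc1ccc(Cl)cc1)c1cc(C(F)(F)F)cc(C(F)(F)F)c1` gives 2300 nM in a toxicity assay on MCF-10A cells (Homo sapiens) for inhibition, read by MTT assay, with a stated time of 72 h (on this read-out lower numbers stand for stronger inhibition of growth and higher numbers for weaker inhibition of growth), the lowest of the three numbers so far; compound 1 `O=S(=O)(NCCCNCc1cccc2ccccc12)c1cc(C(F)(F)F)cc(C(F)(F)F)c1` gives 3200 nM, which sits within the scatter of it, and compound 3 `O=S(=O)(NCCCNCc1cccc(Cl)c1)c1cc(C(F)(F)F)cc(C(F)(F)F)c1` gives 7000 nM. The measured steps are a 1.4-fold lower number from compound 1 to compound 2 (0.14 log units; within the scatter), a 2.2-fold higher number from compound 1 to compound 3 (0.34 log units; beyond the scatter) and a 3.0-fold higher number from compound 2 to compound 3 (0.48 log units; beyond the scatter), each exchanging the whole group on a saturated chain carbon bound to an amine nitrogen. Compound 4 `O=S(=O)(NCCCNCc1ccc(Br)cc1)c1cc(C(F)(F)F)cc(C(F)(F)F)c1` differs from compound 2 by bromo in place of chloro on an aromatic carbon. Among the measured compounds shown here, no measured step exchanges one halogen for another, so no direct guide exists; the exchanges that were measured moved whole groups and even the largest stayed modest. The step expected for compound 4 is therefore a 1.2-fold lower number from compound 2 to compound 4 (0.06 log units; within the scatter), not beyond the scatter. Compound 4 is estimated at 2000 nM, with a range from 900 nM to 4500 nM.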

Compound 4, concentration for 50% growth inhibition: 3100 nM
Estimate against measurement, compound 4: 1.6-fold (0.19 log units) below; low and high end bracket the measured number.
By their numbers in this assay, from the lowest: compounds 2, 4 and 1 (each within the scatter of the next); then compound 3.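

Among these compounds, the first halogen exchange on this aromatic carbon, para to a large group, stays within the scatter (a 1.3-fold higher number from compound 2 to compound 4 (0.13 log units; within the scatter)), so in this assay bromo and chloro cannot be told apart here. The 4-bromophenyl group likewise cannot be told apart from naphthalen-1-yl (a 1.0-fold lower number from compound 1 to compound 4 (0.01 log units; within the scatter)), whereas 3-chlorophenyl stands beyond the scatter of it (a 2.3-fold lower number from compound 3 to compound 4 (0.35 log units; beyond the scatter)). Nothing available here accounts for these readings. Going by these compounds, whether fluoro or a nitrile at this position would stay in the same range remains open. So does whether 3-bromophenyl would repeat the gap seen with 3-chlorophenyl.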